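A few compounds are considered here, and "the series" means these few. Any claim that something is new, unique, unknown or untested is made for them only; others in the source may bear on it.

Measured compounds:
- compound 1, `COc1ccc(-c2cc(/C=C/C(=O)c3ccc(OC)c(OC)c3)[nH]n2)cc1`, gives -78%
- compound 2, `COc1ccc(-c2cc(/C=C/C(=O)c3cc(OC)c(OC)c(OC)c3)[nH]n2)cc1OC`, gives -81%
- compound 3, `COc1ccc(C(=O)/C=C/c2cc(-c3cc(OC)c(OC)c(OC)c3)n[nH]2)cc1`, gives -22%

The read-out is a functional assay on HCT-116 cells (Homo sapiens) for cytotoxicity, read by sulforhodamine B assay, with a stated time of 48 h, tested at 10 uM; a higher number here means a weaker effect of the compound at the concentration tested, a lower number a stronger effect. Within this set of three numbers, compound 3 stands highest, that is the weakest effect at the tested concentration; compound 1 lies nearer to it and compound 2 further from it, and both of those gaps are beyond the usual scatter. Going by the values given here, no single-point step between measured compounds is available, so the size of the change brought by the next modification cannot be read from a measured pair.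

Compound 4, `COc1cc(-c2cc(/C=C/C(=O)c3ccc(F)c(F)c3)[nH]n2)cc(OC)c1OC`, is not yet measured in this assay. Against compound 3 the difference is 3,4-difluorophenyl in place of 4-methoxyphenyl on a carbonyl carbon. The shared core and the rest of the molecule are unchanged. Nothing measured here tracks the effect of exchanging the group on the carbonyl carbon, so the expectation for compound 4 has to stay close to the number of compound 3, with a wide range. The step from compound 3 to compound 4 is expected to be small, at most slightly toward a stronger effect: a number 13 percentage points lower from compound 3 to compound 4 (beyond the scatter). For compound 4 the estimated value in this assay is -35%, with a range from -75% to 5%.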

Compound 4, a percentage reported as activity, at one concentration (the size of the read-out at that concentration, not a potency): 9%
Compound 4: the middle estimate sits 44 percentage points below what was measured; measured number above the stated range.
By their numbers in this assay, from the lowest: compounds 2 and 1 (each within the scatter of the next); then compound 3; then compound 4.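

In this assay the group on a carbonyl carbon proves sensitive to exchange: 3,4-difluorophenyl in place of 4-methoxyphenyl gives a number 31 percentage points higher from compound 3 to compound 4 (beyond the scatter) as a large move toward a weaker effect at the tested concentration. Going by these compounds alone, compound 3 and compound 4 form the first measured pair that differs in one place, so this position now has a measured step with the rest of the molecule unchanged. Nothing measured here explains the size or direction of this step.

As far as these compounds go, it remains open whether the step follows from the loss of 4-methoxyphenyl or the arrival of 3,4-difluorophenyl. An unsubstituted phenyl, a hydroxyphenyl or an aminophenyl on the same carbonyl carbon would help separate these two readings.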